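This account rests on a few compounds, and the source may have more. Where it says the series, first, only, none or still open, it means among the compounds named here.

Compound 1 `O=C1CC(Oc2ncc(F)cn2)CN1c1cnn2c1CN(C(=O)Nc1cc(F)c(F)c(F)c1)C(C1CC1)C2`: 96200 nM
Compound 2 `O=C1c2ccccc2CN1c1cnn2c1CN(C(=O)Nc1cc(F)c(F)c(F)c1)C(C1CC1)C2`: 38500 nM

In a toxicity assay on HepG2 2.2.15 cells (Homo sapiens) for cytotoxicity, read by CellTiter-Glo (on this read-out higher numbers stand for lower toxicity in this test and lower numbers for higher toxicity in this test), compound 1 holds the higher of these two numbers, and the gap down to compound 2 lies beyond the usual scatter. Compound 3 `O=C1CC(c2ccc(F)cc2)CN1c1cnn2c1CN(C(=O)Nc1cc(F)c(F)c(F)c1)C(C1CC1)C2` has not yet been measured. It carries 4-fluorophenyl in place of (5-fluoropyrimidin-2-yl)oxy on a saturated ring carbon. Among the measured compounds shown here, no measured pair differs in just one place, so the only guide is compound 2 at 38500 nM. A moderate downward move in this assay is therefore expected, with the estimated step of a 1.9-fold lower number from compound 1 to compound 3 (0.28 log units; within the scatter). The estimate for compound 3 is 50000 nM, with an expected range of 18000 nM to 100000 nM.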

Compound 3, half-maximal cytotoxic concentration: 32100 nM
Beside the measured number, compound 3's estimate is 1.6-fold (0.19 log units) above it; the measured number falls inside the stated range.
By their numbers in this assay, from the lowest: compounds 3 and 2 (each within the scatter of the next); then compound 1.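

In this assay, this saturated ring carbon of the five-membered ring turns out not to be a silent position: 4-fluorophenyl in place of (5-fluoropyrimidin-2-yl)oxy gives a 3.0-fold lower number from compound 1 to compound 3 (0.48 log units; beyond the scatter), a modest step, but one beyond the usual scatter. No evidence here says what in this exchange produces the step. The swap removes the linking oxygen and changes the ring at once, so a directly attached 5-fluoropyrimidin-2-yl would be needed to separate the two. On these data alone, how an amine or a carboxylic acid would read on this carbon also stays open.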